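Removal of the amino group from compound 1

This account rests on a few compounds, and the source may have more. Where it says the series, first, only, none or still open, it means among the compounds named here.

Compound 1 `Nc1n[nH]c2cc(-c3ccc(=O)n(Cc4cccc(Cl)c4)c3)ccc12` is the reference point of this small set. Going by the values given here, in an assay for inhibition of MAP kinase-interacting serine/threonine-protein kinase 1 (Homo sapiens), read by luminescence and ADP-Glo, with a stated time of 2 h (on this read-out higher numbers stand for weaker inhibition and lower numbers for stronger inhibition), compound 1 gives 11 nM, the lowest of the two numbers measured so far. Among the compounds with values here, its only measured neighbour is compound 2 `CC(=O)Nc1cccc(Cn2cc(-c3ccc4c(N)n[nH]c4c3)ccc2=O)c1`, which in this assay gives 55 nM; the step of a 5.0-fold higher number from compound 1 to compound 2 (0.70 log units; beyond the scatter) is the sole measured step, and it concerns an exchange of acetamido for chloro on an aromatic carbon away from the shared core.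

Compound 3 `O=c1ccc(-c2ccc3cn[nH]c3c2)cn1Cc1cccc(Cl)c1` differs from compound 1 in a different way: hydrogen in place of amino on an aromatic carbon. Within the data shown here, no measured step touches this place; the step from compound 1 to compound 2 leaves the amino group intact and so gives no direct guide. The change is a deletion on the shared core rather than an exchange on the outer aromatic ring, and the set holds nothing to calibrate it. A weaker result than compound 1 is nevertheless expected, with wide uncertainty, as a step of a 27-fold higher number from compound 1 to compound 3 (1.44 log units; beyond the scatter) in this assay. Compound 3 is therefore estimated at 300 nM in this assay, expected to fall between 50 nM and 3000 nM.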

Compound 3, half-maximal inhibitory concentration: 37 nM
For compound 3 the middle estimate is 8.1-fold (0.91 log units) above the measured one, and the stated range ends above it.
By their numbers in this assay, from the lowest: compound 1; then compounds 3 and 2 (each within the scatter of the next).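

In this assay, the amino group on the aromatic carbon of the five-membered aromatic ring contributes to the read-out but is not indispensable: a 3.4-fold higher number from compound 1 to compound 3 (0.53 log units; beyond the scatter) lies beyond the scatter, yet compound 3 still gives 37 nM with only hydrogen in that place. Going by these compounds alone, this is the first measured change on the shared core itself, whereas a 5.0-fold higher number from compound 1 to compound 2 (0.70 log units; beyond the scatter) concerns the outer aromatic ring and leaves the amino group intact, so a change at either place can now be seen to move the number beyond the scatter. Nothing available explains why the number rises when the amino group leaves.

On these data alone, it remains open whether a methyl group, a hydroxyl group or a methylamino group on the same carbon would give a number nearer to that of compound 1 or to that of compound 3. It is also open whether the exchange of acetamido for chloro on the outer aromatic ring would have the same size on a core that carries hydrogen in place of amino, since the compounds shown test each change only against compound 1.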